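Replacing an iodoethenyl with a propynyl on the uracil-bearing nucleoside

The source may hold more compounds than are shown below. What is called first, only, known or untested is meant among the compounds shown, and "the series" means these compounds.

Three compounds have numbers in an ADME assay on L1210/0 cells (Mus musculus) for cytotoxicity, with a stated time of 48 h; a lower number here means a stronger inhibitor, a higher number a weaker inhibitor. Compound 1 `COC1=C(OC)/C(=C/Cn2cnc3c(Cl)ncnc32)OC1=O` gives 14000 nM in this assay. Compound 2 `O=c1[nH]c(=O)n([C@H]2C[C@H](O)[C@@H](CO)O2)cc1/C=C/I` gives 63900 nM in this assay, the higher of the two numbers, and the gap to compound 1 lies beyond the scatter. Compound 3 `Nc1ncnc2c1ncn2[C@@H]1CCC[C@H]1CO` reaches only a limit of the assay, > 200000 nM, so for it no number is known; this is the limit of > 200000 nM in this assay, at which 1 of the 3 values shown sits.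

Compound 4 `CC#Cc1cn([C@H]2C[C@H](O)[C@@H](CO)O2)c(=O)[nH]c1=O` has not yet been measured in this assay. It is related to compound 2 by a single change prop-1-yn-1-yl in place of 2-iodoethenyl on an aromatic carbon: a prop-1-yn-1-yl in place of a 2-iodoethenyl on an aromatic carbon of a six-membered aromatic ring with 2 nitrogen, ortho to a group of 1 heavy atom and two atoms from the ring nitrogen; both groups count 3 heavy atoms and carry neither donors nor acceptors.

Going by the values given here, no step between measured compounds exists, so the size of this one is a matter of expectation only. Compound 4 is expected to give a somewhat lower number than compound 2, a step of a 2.1-fold lower number from compound 2 to compound 4 (0.33 log units; beyond the scatter) that is estimated to be modest, close to the edge of the scatter. Compound 4 is estimated at 30000 nM in this assay, with a range from 8000 nM to 120000 nM.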

Compound 4, half-maximal inhibitory concentration: > 200000 nM
Compound 4 was reported as a limit; the forecaster's own chance of this, stated with the estimate: 10%; middle value at least 6.6-fold (0.82 log units) from the limit.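

In this assay compound 4 gives > 200000 nM as a limit of the assay and not as a number. Prop-1-yn-1-yl in place of 2-iodoethenyl on this aromatic carbon gives an at least 3.1-fold higher number from compound 2 to compound 4 (0.49 log units; beyond the scatter) and is the first step in this set between compounds that differ in one place; it shows that the number depends on which group sits here, even though both groups count 3 heavy atoms and neither carries donors or acceptors. The full size of the step stays unknown, since compound 4 now sits at the same limit as compound 3: the limit of > 200000 nM in this assay, at which 2 of the 4 values shown sit.

The change removes the iodine and replaces the double bond with a triple bond in one move, and the compounds shown do not tell which of the two matters; a 2-bromoethenyl or a prop-1-en-1-yl group on the same carbon would separate them. From the compounds shown here alone, it also remains open whether an ethyl group or a longer alkynyl chain at this position would give a number within the range of the assay.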